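Heteroaryl amide swaps on the bis-hydroxylated tetrahydrofuran series

A few compounds are considered here, and "the series" means these few. Any claim that something is new, unique, unknown or untested is made for them only; others in the source may bear on it.

Three amides on the shared core have been run in a functional assay on SF-539 cells (Homo sapiens) for inhibition, read by colorimetric assay and sulforhodamine B assay, with a stated time of 48 h; on this read-out higher numbers stand for weaker inhibition of growth and lower numbers for stronger inhibition of growth. Compound 1 `CCCCCCCCCCCC[C@@H](O)[C@H]1CC[C@H]([C@H](O)CCCCCCCCCCNC(=O)c2cccs2)O1` gives 17000 nM, compound 2 `CCCCCCCCCCCC[C@@H](O)[C@H]1CC[C@H]([C@H](O)CCCCCCCCCCNC(=O)c2ccco2)O1` gives 81300 nM, and compound 3 `CCCCCCCCCCCC[C@@H](O)[C@H]1CC[C@H]([C@H](O)CCCCCCCCCCNC(=O)c2cncs2)O1` gives 50100 nM. The thiophene-to-furan exchange reads a 4.8-fold higher number from compound 1 to compound 2 (0.68 log units; beyond the scatter), the thiophene-to-thiazole exchange a 2.9-fold higher number from compound 1 to compound 3 (0.47 log units; beyond the scatter), while the furan-to-thiazole exchange reads a 1.6-fold lower number from compound 2 to compound 3 (0.21 log units; within the scatter). Compound 3 thus stands second highest of the three numbers, close to compound 2 and clearly apart from compound 1.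

Compound 4 `CCCCCCCCCCCC[C@@H](O)[C@H]1CC[C@H]([C@H](O)CCCCCCCCCCNC(=O)c2ccnn2C)O1` is obtained from compound 3 by 1-methyl-1H-pyrazol-5-yl in place of 1,3-thiazol-5-yl on a carbonyl carbon. Among the measured compounds shown here, the only step that bears directly on this kind of swap between one five-membered aromatic ring with 2 hetero atoms and another is the one from compound 2 to compound 3, and it lay within the scatter; the two steps out of compound 1 show that such swaps can also move this assay modestly. The expectation for compound 4 is therefore a step of a 1.0-fold lower number from compound 3 to compound 4 (0.00 log units; within the scatter), with no clear direction beyond the scatter. Compound 4 is estimated at 50000 nM, in the range 18000 nM to 140000 nM.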

Compound 4, concentration for 50% growth inhibition: 3720 nM
For compound 4 the middle estimate is 13-fold (1.13 log units) above the measured one; measured number outside the range, below it.
By their numbers in this assay, from the lowest: compound 4; then compound 1; then compounds 3 and 2 (each within the scatter of the next).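

In this assay the ring on the carbonyl carbon can carry a large step (a 13-fold lower number from compound 3 to compound 4 (1.13 log units; beyond the scatter)) and (a 22-fold lower number from compound 2 to compound 4 (1.34 log units; beyond the scatter)), whereas the earlier ring swaps moved the number modestly or within the scatter. Compound 4 also passes compound 1 (a 4.6-fold lower number from compound 1 to compound 4 (0.66 log units; beyond the scatter)), which makes 1-methyl-1H-pyrazol-5-yl the strongest ring of the four and removes thiophen-2-yl from that place. The 1,3-thiazol-5-yl and 1-methyl-1H-pyrazol-5-yl groups have the same counts of hydrogen-bond donors and acceptors, so those counts do not separate compound 3 from compound 4.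

No measurement here offers an explanation for this step. Still open, on these data alone, is whether the methyl or the pyrazole ring carries the gain, which the 1H-pyrazol-5-yl ring without the methyl, or with an ethyl in its place, would separate.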